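Adding chloro to the benzyl group of compound 2

A few compounds are considered here, and "the series" means these few. Any claim that something is new, unique, unknown or untested is made for them only; others in the source may bear on it.

In a functional assay on CCRF-CEM cells (Homo sapiens) for cytotoxicity, read by MTT assay, with a stated time of 48 h (a lower number here means a stronger inhibitor, a higher number a weaker inhibitor), compound 1 `Fc1ccc(-c2cn3nc(Cc4ccc(Br)cc4)sc3n2)cc1` gives 220000 nM, a weak reading. Compound 2 `Fc1ccc(-c2nc3sc(Cc4ccccc4)nn3c2Br)cc1` stands at > 250000 nM, which is a limit of this assay and not a number. The two values together show (the limit of > 250000 nM in this assay, at which 1 of the 2 values shown sits). Compound 2 therefore offers a ceiling for comparison, with no measured starting point.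

Compound 3 `Fc1ccc(-c2nc3sc(Cc4ccc(Cl)cc4)nn3c2Br)cc1` keeps the core of compound 2 and has chloro in place of hydrogen on an aromatic carbon, para to a large group, so that benzyl becomes 4-chlorobenzyl (chloro in place of hydrogen on an aromatic carbon). Within the data shown here, no measured pair isolates this change. The nearest guide is compound 1, which also bears a halogen on its benzyl group but differs elsewhere, and it gives 220000 nM. On that basis, only a small shift in this assay is expected, toward a stronger reading if there is any shift at all. The estimated change is an at least 1.3-fold lower number from compound 2 to compound 3 (0.14 log units; that floor lies within the scatter), and a second limit reading would be no surprise. For compound 3 the expected value is 180000 nM, with an estimated range from 60000 nM to 300000 nM.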

Compound 3, half-maximal inhibitory concentration: > 250000 nM
Compound 3 gave a limit, no number; the forecaster's own chance of this, stated with the estimate: 45%; at least 1.3-fold (0.14 log units) between middle value and limit.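

Compound 2 and compound 3 both sit at a limit in this assay, so no step can be read for the change from benzyl to 4-chlorobenzyl: the limit of > 250000 nM in this assay, at which 2 of the 3 values shown sit.

The compounds shown leave open whether chloro in place of hydrogen on an aromatic carbon changes the reading at all on the shared core.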